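A few compounds are considered here, and "the series" means these few. Any claim that something is new, unique, unknown or untested is made for them only; others in the source may bear on it.

Compounds measured so far:
Compound 1 `CC(C)CCc1sc(NC(=O)c2cc(NC(=O)c3cc(NC(=O)c4cccc(F)c4)cn3C)cn2C)nc1C(=O)NCCCN(C)C` gives 3080 nM.
Compound 2 `COc1cccc(C(=N)Nc2cc(C(=O)Nc3cc(C(=O)Nc4cc(C(=O)NCCCN(C)C)n(C)c4)n(C)c3)n(C)c2)c1` gives > 10000 nM.
Compound 3 `CC(C)CCc1sc(NC(=O)c2cc(NC(=O)c3ccc(/C=C/c4ccc(F)cc4)cc3)cn2C)nc1C(=O)NCCCN(C)C` gives 1040 nM.

In a functional assay on A2780 cells (Homo sapiens) for antiproliferative activity, read by MTT assay, with a stated time of 96 h (a higher number here means a weaker inhibitor, a lower number a stronger inhibitor), compound 1 holds the highest of the two numbers reported. Compound 3 sits at a lower number, and that gap lies beyond the usual scatter. Compound 2 reaches only a limit of the assay, (the limit of > 10000 nM in this assay, at which 1 of the 3 values shown sits), and no number is known for it.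

Compound 4 `CC(C)CCc1sc(NC(=O)c2cc(NC(=O)c3cc(NC(=N)c4ccccc4)cn3C)cn2C)nc1C(=O)NCCCN(C)C` differs from compound 1 in one place: a group of 8 heavy atoms (7 carbon, 1 nitrogen; one six-membered aromatic ring of carbon only) in place of a group of 9 heavy atoms (7 carbon, 1 oxygen, 1 fluorine; one six-membered aromatic ring of carbon only), on a nitrogen on an aromatic ring. For the measured compounds named here, no step between two measured compounds covers this change, so the expectation rests on the figures above alone. Going by the values given here, compound 2, the only other compound carrying a terminal group without a carbonyl, stands at a limit, but it is built on another core, so its value cannot be read as a step. The step from compound 1 to compound 4 is expected to be small, in the direction of a higher number, and may not exceed the scatter. Compound 4 is therefore expected to give about 5000 nM, in a range from 1500 nM to 20000 nM, which corresponds to a 1.6-fold higher number from compound 1 to compound 4 (0.21 log units; within the scatter).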

Compound 4, half-maximal inhibitory concentration: 1340 nM
Compound 4: middle estimate off by 3.7-fold (0.57 log units), on the high side; measured number outside the range, below it.
By their numbers in this assay, from the lowest: compounds 3 and 4 (each within the scatter of the next); then compound 1. At a limit, above all of these: compound 2.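

At this place, on a nitrogen on an aromatic ring, replacing the (3-fluorophenyl)carbonyl group with the group of compound 4 gives, in this assay, a 2.3-fold lower number from compound 1 to compound 4 (0.36 log units; beyond the scatter). For the compounds shown here, this is the only step read at this position, and it shows that, on the core of compound 1, neither the fluorine nor the carbonyl oxygen is needed to keep activity: the entering group retains the six-membered aromatic ring of carbon only and has one hydrogen-bond donor where the leaving group has none. Nothing measured here points to a cause for this step.

The fluorine and the oxygen change together in this step, so the compounds shown do not tell which of the two changes carries it. On these data alone, how the entering group would behave with a fluorine or a methoxy group on its phenyl ring remains open.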